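Swapping the ring on a thiocarbonyl carbon

The compounds below may be only part of what the source reports. "The series", "measured", "known", "first", "only" and "open" are said of these compounds alone.

compound 1 `N/C(=N\NC(=S)N1CCOCC1)c1ccc(F)cn1`: 82.3%
compound 2 `N/C(=N\NC(=S)N1CCCCCC1)c1ccccn1`: 72.3%
compound 3 `Cc1ccnc(/C(N)=N/NC(=S)N2CCOCC2)c1`: 74.6%

In a functional assay on A-431 cells (Homo sapiens) for cytotoxicity, read by MTT assay, with a stated time of 72 h, tested at 30 uM (a lower number here means less inhibition of growth, a higher number more inhibition of growth at the concentration tested), compound 1 gives 82.3%, the highest of the three numbers, yet compound 3 with 74.6% and compound 2 with 72.3% both sit within the usual scatter of it, so none of the three can be called more active than another. Compound 4 `N/C(=N\NC(=S)N1CCCC1)c1ccc(F)cn1` differs from compound 1 in one place: pyrrolidin-1-yl in place of morpholin-4-yl on a thiocarbonyl carbon. Going by the values given here, no measured pair shows this change on its own, and the three measured numbers give no sign that the ring on the thiocarbonyl carbon moves the read-out much. The step from compound 1 to compound 4 is therefore expected to be small, a number 6.3 percentage points lower from compound 1 to compound 4 (within the scatter), not beyond the scatter. Compound 4 is expected to give about 76%, with a range from 60% to 88%.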

Compound 4, percent growth inhibition at one concentration: 83.3%
Beside the measured number, compound 4's estimate is 7.3 percentage points below it, and the stated range covers the measured number.
By their numbers in this assay, from the lowest: compounds 2, 3, 1 and 4 (each within the scatter of the next, the first and the last beyond it).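

In this assay, going by these compounds alone, pyrrolidin-1-yl in place of morpholin-4-yl on a thiocarbonyl carbon gives a number 1 percentage points higher from compound 1 to compound 4 (within the scatter) in the first pair that isolates this swap. At this position, then, a five-membered ring without oxygen can replace a six-membered ring with oxygen, with no change beyond the scatter. Nothing available explains why the read-out holds. Still open, from the compounds shown here alone, is whether an open-chain dimethylamino group or a piperazin-1-yl ring on the same carbon would leave growth inhibition within the scatter too.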